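Thiophene for Phenyl on the Benzyloxy Arm

A few compounds are considered here, and "the series" means these few. Any claim that something is new, unique, unknown or untested is made for them only; others in the source may bear on it.

Compound 3 `CN1CCN(CCCCOc2c(OCc3ccccc3)cc(O)c3c(=O)cc(-c4ccccc4)oc23)CC1` gives 2370 nM in a functional assay on B16 cells (Mus musculus) for cytotoxicity, read by MTT assay, with a stated time of 72 h (on this read-out lower numbers stand for stronger inhibition and higher numbers for weaker inhibition), the lowest of the three numbers shown. Compound 2 `CN(C)CCCCOc1c(OCc2ccccc2)cc(O)c2c(=O)cc(-c3ccccc3)oc12` gives 3220 nM and compound 1 `O=c1cc(-c2ccccc2)oc2c(OCCCN3CCCC3)c(OCc3ccccc3)cc(O)c12` gives 7980 nM; the steps of a 2.5-fold lower number from compound 1 to compound 2 (0.39 log units; beyond the scatter) and a 3.4-fold lower number from compound 1 to compound 3 (0.53 log units; beyond the scatter) lie beyond the scatter, whereas a 1.4-fold lower number from compound 2 to compound 3 (0.13 log units; within the scatter) stays within it. Compound 4 `CN1CCN(CCCCOc2c(OCc3cccs3)cc(O)c3c(=O)cc(-c4ccccc4)oc23)CC1` differs from compound 3 by thiophen-2-yl in place of phenyl on a saturated chain carbon bound to an oxygen on an aromatic ring. As far as these compounds go, all three measured steps alter the amine carried on the chain, so none bears on the exchange of one aromatic ring for another in the benzyloxy group; the size of such a change is unknown here. No step beyond the scatter is therefore expected, with a 1.1-fold higher number from compound 3 to compound 4 (0.02 log units; within the scatter). For compound 4 the estimate is 2500 nM, within a range from 1000 nM to 6500 nM.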

Compound 4, half-maximal inhibitory concentration: 2120 nM
For compound 4 the middle estimate is 1.2-fold (0.07 log units) above the measured one; low and high end bracket the measured number.
By their numbers in this assay, from the lowest: compounds 4, 3 and 2 (each within the scatter of the next); then compound 1.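

In this assay, thiophen-2-yl in place of phenyl on a saturated chain carbon bound to an oxygen on an aromatic ring gives a 1.1-fold lower number from compound 3 to compound 4 (0.05 log units; within the scatter). Within the data shown here, this is the only step here on the benzyloxy arm, and it shows that, with the 4-methylpiperazin-1-yl chain held fixed, this ring exchange leaves the number within the scatter. Nothing given here accounts for this result.

As far as these compounds go, whether furan-2-yl, pyridin-2-yl or a chlorophenyl ring at this place would also stay within the scatter remains open. So does whether thiophen-2-yl would do the same alongside the dimethylamino chain of compound 2.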